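Pyridyl to Benzyl on the Amide Nitrogen

The source may hold more compounds than are shown below. What is called first, only, known or untested is meant among the compounds shown, and "the series" means these compounds.

Compound 1 `CC(=O)Nc1ccc(Cc2noc(CCC(=O)O)n2)cc1` gives 75.3% in a functional assay on the whole organism (strain C57BL/6) for inhibition, with Mus musculus as the target, read by paw edema, with stated times of 1 h and 4 h, at a dose of 100 mg/kg by the oral route; a higher number here means more inhibition at the dose given (going by the name of the read-out), a lower number less inhibition.
Compound 2 `COc1ccc(NC(=O)CCc2nc(Cc3ccc(NC(C)=O)cc3)no2)cc1OC` gives 95.9%.
Compound 3 `CC(=O)Nc1ccc(Cc2noc(CCC(=O)Nc3cccnc3)n2)cc1` gives 87.7%.

The three measured compounds share one core and differ only at the end of the chain that carries the carbonyl. Compound 3 stands second highest of the three numbers: its nearest neighbour is compound 2, its furthest compound 1. Of the two steps that lead to it, a number 12.4 percentage points higher from compound 1 to compound 3 (beyond the scatter) lies beyond the scatter, whereas a number 8.2 percentage points lower from compound 2 to compound 3 (within the scatter) lies within it.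

Compound 4 `CC(=O)Nc1ccc(Cc2noc(CCC(=O)NCc3ccccc3)n2)cc1` has not yet been measured. Its change from compound 3 is benzyl in place of pyridin-3-yl on an amide-type nitrogen. Among the compounds with values here, the step that bears on this change is the one between compound 2 and compound 3, where one aryl group replaced another on the same amide-type nitrogen and the number stayed within the scatter. The step from compound 1 removes the amide altogether and so says little here. Compound 4 is therefore expected to show no step beyond the scatter, a number 2.7 percentage points lower from compound 3 to compound 4 (within the scatter). The estimate for compound 4 is 85%, with a range from 70% to 96%.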

Compound 4, a percentage reported as inhibition, in the whole organism at one dose (the size of the read-out at that dose, not a potency): 76.7%
Beside the measured number, compound 4's estimate is 8.3 percentage points above it, within the range that was stated.
By their numbers in this assay, from the lowest: compounds 1 and 4 (each within the scatter of the next); then compounds 3 and 2 (each within the scatter of the next).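

In this assay the amide-type nitrogen turns out to be sensitive to its substituent, which the earlier swap of one aryl group for another did not show: there is a number 11 percentage points lower from compound 3 to compound 4 (beyond the scatter) and also a number 19.2 percentage points lower from compound 2 to compound 4 (beyond the scatter) when benzyl is the group on that nitrogen. Making the amide does not always separate a compound from the acid, since benzylamino in place of hydroxy gives a number 1.4 percentage points higher from compound 1 to compound 4 (within the scatter) while the (pyridin-3-yl)amino amide stood beyond the scatter from it. No measurement at hand explains why benzyl differs from the two aryl groups. 

Benzyl differs from pyridin-3-yl both in its methylene link and in lacking the ring nitrogen, and the compounds shown cannot separate these two differences. A plain phenyl or a pyridin-3-ylmethyl group on the same nitrogen would be needed to tell them apart.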